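This account rests on a few compounds, and the source may have more. Where it says the series, first, only, none or still open, it means among the compounds named here.

Measured so far in a functional assay on HT-29 cells (Homo sapiens) for antiproliferative activity, read by sulforhodamine B assay, with a stated time of 48 h; a lower number here means a stronger inhibitor, a higher number a weaker inhibitor:
compound 1, `CC(C)c1ccccc1OS(=O)(=O)c1cccc(NC(=O)C(C)(C)C)c1`, gives 19000 nM;
compound 2, `CCC(=O)Nc1ccc(S(=O)(=O)Oc2ccccc2C(C)C)cc1`, gives 7400 nM;
compound 3, `CCC(=O)Nc1ccc(S(=O)(=O)Oc2ccccc2I)cc1`, gives 11000 nM.

Among these three numbers compound 3 stands second highest; its nearest neighbour is compound 2 and its furthest compound 1, both within the usual scatter. Going by the values given here, the single known step, a 1.5-fold higher number from compound 2 to compound 3 (0.17 log units; within the scatter), changes a substituent on an aromatic carbon and says nothing about the amide chain. Compound 4, `CCCC(=O)Nc1ccc(S(=O)(=O)Oc2ccccc2I)cc1`, differs from compound 3 by methyl in place of hydrogen on a saturated chain carbon, two bonds along the chain from a carbonyl carbon. Among the compounds with values here, no measured step touches this chain, so no movement beyond the scatter is expected, and the estimated step is no change at the digits printed from compound 3 to compound 4 (within the scatter). Compound 4 is therefore expected to give about 11000 nM in this assay, with a likely range from 5000 nM to 25000 nM.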

Compound 4, half-maximal inhibitory concentration: 11000 nM
The estimate for compound 4 equals the measured number at the digits printed; the measured number falls inside the stated range.
By their numbers in this assay, from the lowest: compounds 2, 3, 4 and 1 (each within the scatter of the next, the first and the last beyond it).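

Going by these compounds alone, the step from propanoyl to propylcarbonyl, methyl in place of hydrogen on a saturated chain carbon, two bonds along the chain from a carbonyl carbon, is the first measured change in the amide chain, and in this assay it brings no change at the digits printed from compound 3 to compound 4 (within the scatter) for this pair. With iodo on the shared core, this position therefore takes one added methyl without a shift beyond the scatter. Nothing measured here offers an explanation for this result.

From the compounds shown here alone, whether a much longer chain, an amine or a carboxylic acid at this position would also leave the number within the scatter remains open. So does whether the same added methyl would read alike with isopropyl in place of iodo.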